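The source may hold more compounds than are shown below. What is called first, only, known or untested is meant among the compounds shown, and "the series" means these compounds.

The compounds measured so far:

compound 1 `O=C(Nc1cccc(-c2cccc(F)c2)c1)C(Cl)Cl` — > 50000 nM, a limit of the assay
compound 2 `CC(C)Oc1ccc(-c2cc(NC(=O)C(Cl)Cl)cc(-c3ccc(OC(C)C)cc3)c2)cc1` — 8850 nM
compound 3 `CCOc1ccccc1-c1cc(NC(=O)C(Cl)Cl)cc(-c2ccccc2OCC)c1` — 8730 nM

For the measured compounds named here, in a functional assay on KB 3-1 cells (Homo sapiens) for cytotoxicity, read by MTT assay, with a stated time of 68 h (a higher number here means a weaker inhibitor, a lower number a stronger inhibitor), compound 1 gives only > 50000 nM, which is a limit of the assay and not a number; it is the one compound sitting at the limit of > 50000 nM in this assay, at which 1 of the 3 values shown sits. Compound 2 gives 8850 nM and compound 3 gives 8730 nM in this assay; the two values lie close to each other and both carry two aryl groups on the core, unlike compound 1, which carries only one. Going by the values given here, no pair of these three compounds differs in a single place, so no measured step is available to carry over.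

Compound 4 `COc1cccc(-c2cccc(NC(=O)C(Cl)Cl)c2)c1` has not yet been measured in this assay. It differs from compound 1 by methoxy in place of fluoro on an aromatic carbon. Among the compounds with values here, the change is small and keeps the single-aryl arrangement of compound 1, and nothing among the measured compounds speaks for a move beyond the scatter from that starting point. The step from compound 1 to compound 4 is therefore expected to be a step that the limit leaves unreadable from compound 1 to compound 4, which is to say none beyond the scatter. Compound 4 is estimated at 60000 nM in this assay, with a range from 15000 nM to 200000 nM, and it is quite likely that the assay again reports only a limit.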

Compound 4, half-maximal inhibitory concentration: 43300 nM
Estimate against measurement, compound 4: 1.4-fold (0.14 log units) above, and the stated range covers the measured number.
By their numbers in this assay, from the lowest: compounds 3 and 2 (each within the scatter of the next); then compound 4. At a limit, above all of these: compound 1.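

In this assay compound 1 stands only at a limit of the assay, > 50000 nM, and that limit is not a number. With methoxy in place of fluoro on an aromatic carbon, meta to a large group, the single-aryl arrangement now has a measured value, and the change gives an at least 1.1-fold lower number from compound 1 to compound 4 (0.06 log units; that floor lies within the scatter), so the data show a floor for this step and no move beyond the scatter. The real size of the step may be larger, but it cannot be read any further because one end of it is a limit: the limit of > 50000 nM in this assay, at which 1 of the 4 values shown sits.

The compounds shown leave open what other groups would do at this same place, for example a hydroxyl, an amine or a longer chain such as ethoxy, and whether any of them would move the value clearly beyond the scatter. For the compounds shown here, they also leave open whether methoxy in place of fluoro would give a similar step on a core that carries two aryl groups, since no pair of that kind stands among them.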